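Chloro to Bromo at the Edge of Detection

The compounds below may be only part of what the source reports. "The series", "measured", "known", "first", "only" and "open" are said of these compounds alone.

Compound 1 `O=C(Nc1ccc(Oc2ccnc3[nH]ccc23)cc1)c1nn(-c2ccc(Cl)cc2)ccc1=O` gives 19500 nM in a functional assay on HepG2 cells (Homo sapiens) for cytotoxicity, read by MTT assay, with a stated time of 72 h; on this read-out lower numbers stand for stronger inhibition and higher numbers for weaker inhibition. Compound 2 `O=C(Nc1ccc(Oc2ccnc3[nH]ccc23)c(F)c1)c1nn(-c2ccc(Cl)cc2)ccc1=O` is the fluoro analogue of compound 1. In this assay compound 2 reaches only the limit and reports > 60000 nM. For the measured compounds named here, the single measured step, an at least 3.0-fold higher number from compound 1 to compound 2 (0.48 log units; beyond the scatter), is bounded by the limit of > 60000 nM in this assay, at which 1 of the 2 values shown sits. Compound 3 `O=C(Nc1ccc(Oc2ccnc3[nH]ccc23)c(F)c1)c1nn(-c2ccc(Br)cc2)ccc1=O` differs from compound 2 by bromo in place of chloro on an aromatic carbon. Going by the values given here, no measured step bears on this change, and no movement beyond the scatter is expected. With compound 2 already at the limit, compound 3 is expected to remain there as well. Compound 3 is therefore estimated at 70000 nM, within 30000 nM to 200000 nM. The expected step is a step that the limit leaves unreadable from compound 2 to compound 3.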

Compound 3, half-maximal inhibitory concentration: 68000 nM
For compound 3 the middle estimate is 1.0-fold (0.01 log units) above the measured one; the measured number falls inside the stated range.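

No step from compound 2 to compound 3 can be read, because compound 2 gives only a limit: the limit of > 60000 nM in this assay, at which 1 of the 3 values shown sits.

The compounds shown leave open whether 4-bromophenyl in place of 4-chlorophenyl changes the value at all.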